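Lengthening the hydroxycarbamoyl chain of compound 2

The source may hold more compounds than are shown below. What is called first, only, known or untested is meant among the compounds shown, and "the series" means these compounds.

In a functional assay on NCI-H838 cells (Homo sapiens) for antiproliferative activity, read by MTT assay, with a stated time of 72 h (on this read-out lower numbers stand for stronger inhibition and higher numbers for weaker inhibition), compound 2 `C=CC(=O)Nc1cc2c(Nc3ccc(F)c(Cl)c3)ncnc2cc1OCc1cn(CCC(=O)NO)nn1` gives > 50000 nM as a limit and not a number. Compound 1 `C=CC(=O)Nc1cc2c(Nc3ccc(OCc4cccc(F)c4)c(Cl)c3)ncnc2cc1OCc1cn(CCCC(=O)NO)nn1` gives > 50000 nM as a limit too. This is the limit of > 50000 nM in this assay, at which 2 of the 3 values shown sit, and no number can be read from it. Compound 3 `CN(C)C/C=C/C(=O)Nc1cc2ncnc(Nc3ccc(F)c(Cl)c3)c2cc1O[C@@H]1CCOC1` reads 9920 nM in this assay as an actual number. Compound 4 `C=CC(=O)Nc1cc2c(Nc3ccc(F)c(Cl)c3)ncnc2cc1OCc1cn(CCCCC(=O)NO)nn1` carries 2-(hydroxycarbamoyl)ethyl in place of hydroxycarbamoyl on a saturated chain carbon, two bonds along the chain from an aromatic nitrogen, as 2-(hydroxycarbamoyl)ethyl in place of hydroxycarbamoyl on a saturated chain carbon, two bonds along the chain from an aromatic nitrogen sets out against compound 2. For the measured compounds named here, no measured step gauges this change. A small shift toward stronger inhibition is expected in this assay with an at least 1.4-fold lower number from compound 2 to compound 4 (0.15 log units; that floor lies within the scatter) as the estimate, and another limit remains possible. Compound 4 is estimated at 35000 nM with 10000 nM to 70000 nM as the expected range.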

Compound 4, half-maximal inhibitory concentration: > 50000 nM
Compound 4 ended at the assay's limit; the forecaster's own chance of this, stated with the estimate: 55%; middle value at least 1.4-fold (0.15 log units) from the limit.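

No step can be read between compound 2 and compound 4 because both stand at a limit in this assay: the limit of > 50000 nM in this assay, at which 3 of the 4 values shown sit.

The compounds shown leave open whether 2-(hydroxycarbamoyl)ethyl in place of hydroxycarbamoyl changes antiproliferative activity at all.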